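A few compounds are considered here, and "the series" means these few. Any claim that something is new, unique, unknown or untested is made for them only; others in the source may bear on it.

Measured compounds:
- compound 1, `O=C(OCc1ccccc1)N1CCN(C(=S)SCc2cn(Cc3ccc(F)cc3)nn2)CC1`, 17600 nM
- compound 2, `COc1ccc(Cn2cc(CSC(=S)N3CCN(C(=O)OCc4ccccc4)CC3)nn2)cc1`, 23800 nM
- compound 3, `S=C(SCc1cn(Cc2ccc(Cl)cc2)nn1)N1CCNCC1`, "not determined" (no result reported)

Compounds 1 and 2 share the whole of their framework with compound 3 apart from what sits on one ring nitrogen and on one aromatic carbon. In a functional assay on MGC-803 cells (Homo sapiens) for inhibition, read by MTT assay, with a stated time of 72 h (on this read-out lower numbers stand for stronger inhibition and higher numbers for weaker inhibition), compound 1 gives 17600 nM, and compound 2 gives 23800 nM. For the measured compounds named here, the only step between two measured compounds that differ in a single place is a 1.4-fold higher number from compound 1 to compound 2 (0.13 log units; within the scatter), a change on an aromatic carbon.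

Compound 3 stands nowhere on these numbers: no result was reported for it in this assay, so it offers no anchor of its own.

Compound 4, `O=C(OCc1ccccc1)N1CCN(C(=S)SCc2cn(Cc3ccc(Cl)cc3)nn2)CC1`, arises from compound 3 by the change (benzyloxycarbonyl in place of hydrogen on an amine nitrogen in a ring). Going by the values given here, no measured step touches this ring nitrogen, so the single step known, from compound 1 to compound 2, does not bear on the change itself; it concerns a different position and was within the scatter. What does bear on compound 4 is that it carries the same benzyloxycarbonyl group as compounds 1 and 2 and differs from each of them only in the substituent on the aromatic carbon. The expectation for compound 4 therefore rests on those two values. Compound 4 is expected to give about 19000 nM in this assay, within a range from 8000 nM to 45000 nM.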

Compound 4, half-maximal inhibitory concentration: 31300 nM
Estimate against measurement, compound 4: 1.6-fold (0.22 log units) below; the range from low to high includes it.
By their numbers in this assay, from the lowest: compounds 1, 2 and 4 (each within the scatter of the next).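

In this assay, chloro in place of methoxy on the aromatic carbon gives a 1.3-fold higher number from compound 2 to compound 4 (0.12 log units; within the scatter), and chloro in place of fluoro gives a 1.8-fold higher number from compound 1 to compound 4 (0.25 log units; within the scatter). With benzyloxycarbonyl on the ring nitrogen, three different substituents can now be compared on this aromatic carbon, and none of the steps among compound 1, compound 2 and compound 4 goes beyond the scatter, so swapping among fluoro, methoxy and chloro has no readable effect on the number. No accompanying measurement offers an explanation for how closely these values sit.

From the compounds shown here alone, compound 3 has no reported result, so the step from hydrogen to benzyloxycarbonyl on the ring nitrogen cannot be read, and what that group contributes to the number stays unknown. Also open, going by these compounds, is whether a different kind of group on the aromatic carbon, such as an amine or a carboxylic acid, or an acetyl group in place of benzyloxycarbonyl on the ring nitrogen, would shift the number beyond the scatter.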